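Aryl variation on the ring amide nitrogen of the core

This account rests on a few compounds, and the source may have more. Where it says the series, first, only, none or still open, it means among the compounds named here.

Measured so far:
- compound 1 `COc1ccc(OC)c(N2C(=O)CSC2c2cccc(C(=O)NCCCCc3ccccc3)c2)c1`: > 1000 nM in a functional assay on HOS-TE85 cells (Homo sapiens) for inhibition, read by CCK-8 assay, with a stated time of 72 h; on this read-out higher numbers stand for weaker inhibition and lower numbers for stronger inhibition
- compound 2 `O=C(NCCCCc1ccccc1)c1cccc(C2SCC(=O)N2c2ccccc2)c1`: 15.9 nM
- compound 3 `O=C(NCCCCc1ccccc1)c1cccc(C2SCC(=O)N2c2ccc(-c3ccccc3)cc2)c1`: > 1000 nM

Compound 3 stands at the assay limit; its value in this assay is a limit, not a number. The same holds for compound 1, whose value is a limit as well (the limit of > 1000 nM in this assay, at which 2 of the 3 values shown sit). Compound 2 alone gives a number, and the step of an at least 62-fold higher number from compound 2 to compound 3 (1.79 log units; beyond the scatter) is large. The step of an at least 62-fold lower number from compound 1 to compound 2 (1.79 log units; beyond the scatter) is likewise large, whereas a step that the two limits leave unreadable from compound 1 to compound 3 cannot be sized between the two limits.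

Compound 4 `COc1ccc(N2C(=O)CSC2c2cccc(C(=O)NCCCCc3ccccc3)c2)c(OC)c1` differs from compound 3 by 2,4-dimethoxyphenyl in place of 4-phenylphenyl on an amide-type nitrogen in a ring. Going by the values given here, two steps bear on this: the loss of the 4-phenylphenyl group recalls the step from compound 2 to compound 3, but the entering 2,4-dimethoxyphenyl sits close to the 2,5-dimethoxyphenyl of compound 1, which also reaches only the limit. With no number on either side, no readable step is expected; compound 4 is expected to sit at the limit too, a step that the limit leaves unreadable from compound 3 to compound 4. The estimate for compound 4 is 1500 nM, within 300 nM to 6000 nM.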

Compound 4, half-maximal inhibitory concentration: 90.4 nM
Compound 4: the middle estimate sits 17-fold (1.22 log units) above what was measured; measured number outside the range, below it.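

In this assay, a dimethoxyphenyl group on the amide-type nitrogen in the ring is not in itself enough to take a compound to the limit, as the 2,4-dimethoxyphenyl of compound 4 gives a number, with an at least 11-fold lower number from compound 3 to compound 4 (1.04 log units; beyond the scatter). The arrangement of the two methoxy groups matters at this position, since exchanging 2,5-dimethoxyphenyl for 2,4-dimethoxyphenyl gives an at least 11-fold lower number from compound 1 to compound 4 (1.04 log units; beyond the scatter). Plain phenyl still reads best among the compounds shown, but the price of the two methoxy groups in 2,4-dimethoxyphenyl is only modest, with a 5.7-fold higher number from compound 2 to compound 4 (0.75 log units; beyond the scatter).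

From the compounds shown here alone, the step between compound 1 and compound 3 cannot be read, as both values are limits: the limit of > 1000 nM in this assay, at which 2 of the 4 values shown sit. Also open is how a phenyl bearing a single methoxy group, a dimethylamino group or a carboxylic acid would read on this nitrogen.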